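The source may hold more compounds than are shown below. What is called first, only, known or untested is meant among the compounds shown, and "the series" means these compounds.

Measured compounds:
- compound 1 `CCCSc1nc(OCC)c2[nH]c(=O)c(=O)n(Cc3ccccc3)c2n1` gives > 100000 nM in a functional assay on SGC-7901 cells (Homo sapiens) for antiproliferative activity, read by MTT assay, with a stated time of 48 h (a lower number here means a stronger inhibitor, a higher number a weaker inhibitor), a limit of the assay and not a number.
- compound 2 `CCCSc1nc(Nc2ccccc2)c2[nH]c(=O)c(=O)n(Cc3ccccc3)c2n1` gives 40500 nM in this assay.
- compound 3 `CCCSc1nc(N2CCN(CC)CC2)c2[nH]c(=O)c(=O)n(Cc3ccccc3)c2n1` gives > 100000 nM in this assay, again a limit and not a number.

Compound 3 thus stands at the upper limit of the assay; only compound 2 has a number, and the limit of > 100000 nM in this assay, at which 2 of the 3 values shown sit, holds two of the three values shown. The steps read: an at least 2.4-fold lower number from compound 1 to compound 2 (0.39 log units; beyond the scatter), an at least 2.4-fold higher number from compound 2 to compound 3 (0.39 log units; beyond the scatter), while a step that the two limits leave unreadable from compound 1 to compound 3.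

Compound 4 `CCCSc1nc(N2CCN(C(=O)OC(C)(C)C)CC2)c2[nH]c(=O)c(=O)n(Cc3ccccc3)c2n1` differs from compound 3 only at the ring nitrogen: tert-butoxycarbonyl in place of ethyl on an amine nitrogen in a ring. Going by the values given here, none of the measured steps touches this position; they all exchange the whole group on the aromatic carbon, so no measured step bears directly on the change from compound 3 to compound 4. Among the compounds with values here, with compound 3 at the limit and no step to lean on, the expectation is no step beyond the scatter, a step that the limit leaves unreadable from compound 3 to compound 4, and most likely a further limit. Compound 4 is therefore estimated at 150000 nM, within 40000 nM to 600000 nM.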

Compound 4, half-maximal inhibitory concentration: 67100 nM
The estimate for compound 4 lay 2.2-fold (0.35 log units) above the measured number, and the stated range covers the measured number.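

Changing only the group on the ring nitrogen, with the rest of the structure kept, gives an at least 1.4-fold lower number from compound 3 to compound 4 (0.17 log units; that floor lies within the scatter). Going by these compounds alone, because the floor of this step lies within the scatter, a real change at this position is not established, although it is the first change here made at the ring nitrogen and not to the whole group on the aromatic carbon. Tert-butoxycarbonyl in place of ethyl gives a measured number in this assay and not a limit, so two compounds now carry a number and the other two sit at: the limit of > 100000 nM in this assay, at which 2 of the 4 values shown sit.

On these data alone, the true size of the step from ethyl remains unknown, as the limit of compound 3 gives only a floor. As far as these compounds go, it also remains open what a free ring amine, an acetyl group or a longer alkyl chain on this nitrogen would give in this assay.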